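From propyl to cyclopentyl on the urea nitrogen

This account rests on a few compounds, and the source may have more. Where it says the series, first, only, none or still open, it means among the compounds named here.

Measured in a functional assay on MCF7 cells (Homo sapiens) for antiproliferative activity, read by sulforhodamine B assay, with a stated time of 48 h; a higher number here means a weaker inhibitor, a lower number a stronger inhibitor:
compound 1 `CCC(=O)Nc1ccc(S(=O)(=O)Oc2ccccc2C(C)C)cc1` gives 11000 nM
compound 2 `CCCCCC(=O)Nc1ccc(S(=O)(=O)Oc2ccccc2C(C)C)cc1` gives 5300 nM
compound 3 `CCCNC(=O)Nc1ccc(S(=O)(=O)Oc2ccccc2C(C)C)cc1` gives 2700 nM

Compound 3 shows the lowest number of the three: a 4.1-fold lower number from compound 1 to compound 3 (0.61 log units; beyond the scatter) lies beyond the scatter, but a 2.0-fold lower number from compound 2 to compound 3 (0.29 log units; within the scatter) does not, so compound 3 and compound 2 cannot be ranked against each other. Compound 4 `CC(C)c1ccccc1OS(=O)(=O)c1ccc(NC(=O)NC2CCCC2)cc1` differs from compound 3 by cyclopentyl in place of propyl on an amide-type nitrogen. Within the data shown here, no measured step alters that group. The nearest comparison is a 2.1-fold lower number from compound 1 to compound 2 (0.32 log units; beyond the scatter), where a longer chain brought a modest gain, while a 2.0-fold lower number from compound 2 to compound 3 (0.29 log units; within the scatter) stayed within the scatter. A small step is therefore expected in this assay, more likely down than up, and the estimate for compound 4 is 1800 nM, between 600 nM and 5000 nM, a step of a 1.5-fold lower number from compound 3 to compound 4 (0.18 log units; within the scatter).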

Compound 4, half-maximal inhibitory concentration: 6200 nM
Compound 4: the middle estimate sits 3.4-fold (0.54 log units) below what was measured, outside the stated range (above it).
By their numbers in this assay, from the lowest: compounds 3, 2, 4 and 1 (each within the scatter of the next, the first and the last beyond it).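

On the amide-type nitrogen, the change from propyl to cyclopentyl gives a 2.3-fold higher number from compound 3 to compound 4 (0.36 log units; beyond the scatter) in this assay, so this position does respond to the group it carries, and more carbon here did not bring a lower number. Against the two amides, the urea with cyclopentyl shows no clear difference: a 1.2-fold higher number from compound 2 to compound 4 (0.07 log units; within the scatter) and a 1.8-fold lower number from compound 1 to compound 4 (0.25 log units; within the scatter) both stay within the scatter. No available evidence explains the step from propyl to cyclopentyl. Going by these compounds, whether the ring or the larger carbon count matters remains open, and pentyl or cyclopropyl on this nitrogen would help separate the two.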